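The source may hold more compounds than are shown below. What is called first, only, known or untested is meant among the compounds shown, and "the series" means these compounds.

Measured so far:
Compound 1 `CC(O)c1cn(Cc2cc(=O)oc3cc(O)ccc23)nn1` in a functional assay on SW-620 cells (Homo sapiens) for inhibition, read by MTT assay, with a stated time of 72 h (on this read-out lower numbers stand for stronger inhibition and higher numbers for weaker inhibition), gives > 100000 nM, which is a limit of the assay rather than a number.
Compound 2 `O=c1cc(Cn2cc(CCCO)nn2)c2ccc(O)cc2o1` in this assay gives > 100000 nM, again a limit.

Both values sit at the limit of > 100000 nM in this assay, at which 2 of the 2 values shown sit, so the step that the two limits leave unreadable from compound 1 to compound 2 cannot be sized. Compound 2 therefore stands only at the limit. Compound 3 `CC(C)(C)c1cn(Cc2cc(=O)oc3cc(O)ccc23)nn1` is not yet measured; its change from compound 2 is tert-butyl in place of 3-hydroxypropyl on an aromatic carbon. For the measured compounds named here, no measured step reads on this exchange, since the only step, from a 1-hydroxyethyl to a 3-hydroxypropyl group, lies between two limits. With no readable step, compound 3 is expected to remain at the limit as well: estimate 150000 nM, range 50000 nM to 500000 nM, meaning an expected step that the limit leaves unreadable from compound 2 to compound 3.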

Compound 3, half-maximal inhibitory concentration: > 100000 nM
Compound 3: no number, only a limit; the forecaster's own chance of this, stated with the estimate: 90%; the middle value does not contradict the limit.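

In this assay, for the compounds shown here, compound 3 gives > 100000 nM, again a limit, so no step among compound 1, compound 2 and compound 3 can be read. What these compounds leave open is whether any group at this place gives measurable inhibition.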